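Swapping a Sulfonyl for a Carbamoyl on the Shared Core

A few compounds are considered here, and "the series" means these few. Any claim that something is new, unique, unknown or untested is made for them only; others in the source may bear on it.

Of the compounds shown here, three sharing one core have been tested in a functional assay on KB cells (Homo sapiens) for antiproliferative activity, read by MTT assay, with a stated time of 72 h; a lower number here means a stronger inhibitor, a higher number a weaker inhibitor: compound 1 `CN(C(=O)c1ccc(F)cc1)c1ccc2[nH]c(-c3n[nH]c4ccccc34)cc2n1` gives 7220 nM, compound 2 `CN(C(=O)c1ccco1)c1ccc2[nH]c(-c3n[nH]c4ccccc34)cc2n1` gives 19400 nM, and compound 3 `CN(c1ccc2[nH]c(-c3n[nH]c4ccccc34)cc2n1)S(=O)(=O)c1ccc(Br)cc1` gives 7150 nM. Compound 3 holds the lowest of the three numbers, though its gap to compound 1 lies within the scatter; only compound 2 sits clearly higher. Compound 4 `CN(C(=O)Nc1ccccc1)c1ccc2[nH]c(-c3n[nH]c4ccccc34)cc2n1` carries phenylcarbamoyl in place of (4-bromophenyl)sulfonyl on a nitrogen on an aromatic ring. Two earlier steps touch the same nitrogen: a 1.0-fold lower number from compound 1 to compound 3 (0.00 log units; within the scatter) and a 2.7-fold lower number from compound 2 to compound 3 (0.43 log units; beyond the scatter). The first shows that exchanging a carbonyl-bearing group for a sulfonyl group there changed little; the second shows a modest shift when the ring attached to the carbonyl changed. A step of at most modest size, with no clear direction, is therefore expected, giving a 1.1-fold higher number from compound 3 to compound 4 (0.05 log units; within the scatter). Compound 4 is expected to give 8000 nM, within 3000 nM to 25000 nM.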

Compound 4, half-maximal inhibitory concentration: 32 nM
Estimate against measurement, compound 4: 250-fold (2.40 log units) above; the measured number lies below the stated range.
By their numbers in this assay, from the lowest: compound 4; then compounds 3 and 1 (each within the scatter of the next); then compound 2.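

In this assay, going by these compounds alone, this nitrogen proves far more sensitive than the earlier compounds showed: phenylcarbamoyl in place of (4-bromophenyl)sulfonyl gives a 220-fold lower number from compound 3 to compound 4 (2.35 log units; beyond the scatter) and stands out from the earlier swaps there, which were small or modest. Anilino on the carbonyl carbon gives a 230-fold lower number from compound 1 to compound 4 (2.35 log units; beyond the scatter) in place of 4-fluorophenyl and a 610-fold lower number from compound 2 to compound 4 (2.78 log units; beyond the scatter) in place of furan-2-yl, so a carbonyl alone does not produce the large step. The entering group counts one hydrogen-bond donor, whereas the leaving group counts none.

Nothing available explains the size of this step. Open, as far as these compounds go, is whether a methyl on the anilino nitrogen, or a longer chain leading to the phenyl ring, would keep the low number.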